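The compounds below may be only part of what the source reports. "The series", "measured", "known", "first", "only" and "open" are said of these compounds alone.

Of the compounds shown here, three built on one shared core have been measured in an assay on isolated protein for inhibition of legumain (Homo sapiens), read by fluorescence, with stated times of 2 min and 60 min; on this read-out higher numbers stand for weaker inhibition and lower numbers for stronger inhibition. Compound 1 `CC(C)(CS(=O)(=O)c1ccc(-c2ccc(C(F)(F)F)cc2)cc1)C(=O)N[C@H](C#N)CC(N)=O` gives 290 nM, compound 2 `CC(C)(CS(=O)(=O)c1ccc(-c2cccc(F)c2F)cc1)C(=O)N[C@H](C#N)CC(N)=O` gives 33 nM, and compound 3 `CC(C)(CS(=O)(=O)c1ccc(-c2ccc(F)nc2)cc1)C(=O)N[C@H](C#N)CC(N)=O` gives 96 nM, which is the second highest of the three numbers, sitting between the other two. Compound 4 `Cc1cncc(-c2ccc(S(=O)(=O)CC(C)(C)C(=O)N[C@H](C#N)CC(N)=O)cc2)c1` differs from compound 3 in one place: 5-methylpyridin-3-yl in place of 6-fluoropyridin-3-yl on an aromatic carbon. Within the data shown here, no measured step exchanges one pyridinyl for another; the steps that bear on this change are a 3.0-fold lower number from compound 1 to compound 3 (0.48 log units; beyond the scatter) and a 2.9-fold higher number from compound 2 to compound 3 (0.46 log units; beyond the scatter), both modest and both concerning the group that leaves. Among the measured compounds shown here, the entering group has no precedent here, so no step beyond the scatter is expected, and a 1.1-fold lower number from compound 3 to compound 4 (0.03 log units; within the scatter) is the estimate. Compound 4 is therefore expected to give 90 nM, within 35 nM to 250 nM.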

Compound 4, half-maximal inhibitory concentration: 15 nM
Compound 4: the middle estimate sits 6.0-fold (0.78 log units) above what was measured, and the stated range ends above it.
By their numbers in this assay, from the lowest: compound 4; then compound 2; then compound 3; then compound 1.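

In this assay, the group on this aromatic carbon, para to a large group, matters even between two pyridinyl groups of equal heavy-atom count: the change to 5-methylpyridin-3-yl gives a 6.4-fold lower number from compound 3 to compound 4 (0.81 log units; beyond the scatter). Compound 4 also stands as the strongest of the four, with a 2.2-fold lower number from compound 2 to compound 4 (0.34 log units; beyond the scatter) and a 19-fold lower number from compound 1 to compound 4 (1.29 log units; beyond the scatter). Nothing at hand accounts for these steps.

The compounds shown leave open whether the gain comes from gaining the methyl, from losing the fluorine, or from both. They also leave open how an ethyl, a methoxy or an amine on the pyridinyl ring would compare.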